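The source may report more compounds than this note shows. Statements on the series, on what has been measured and on what is new or still open speak of the compounds shown alone.

Measured so far:
- compound 1, `COc1ccc(Oc2ccc3c(NCCCNCc4cc(F)ccc4OC)ccnc3c2)cc1` — 9.28
- compound 2, `COc1ccc(Oc2ccc3c(NCCCNCc4cccc(OC)c4O)ccnc3c2)cc1` — 9.28

In a physicochemical assay for acid dissociation, compound 1 gives 9.28 and compound 2 gives 9.28. Going by the values given here, the one measured step, no change at the digits printed from compound 1 to compound 2 (within the scatter), swaps the aryl group on the saturated chain carbon bound to the amine nitrogen and leaves the read-out where it was. Compound 2 thus stands level with compound 1 at the digits shown.

Compound 3, `COc1cccc(CNCCCNc2ccnc3cc(Cc4ccccc4)ccc23)c1O`, differs from compound 2 on the fused ring system of the shared core: benzyl in place of 4-methoxyphenoxy on an aromatic carbon. Among the compounds with values here, no measured step touches this position; the only step on record concerns the aryl group on the chain and gave no change beyond the scatter. The chain amine, the group most likely to set the read-out, is untouched in compound 3, and the exchange on the core is far from it. On that basis no shift beyond the scatter is expected in this assay, in either direction.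

Compound 3 is therefore estimated at 9.3, with a range from 9 to 9.6. The expected step is a number 0.02 log units higher from compound 2 to compound 3 (within the scatter).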

Compound 3, acid dissociation constant: 9.47
Beside the measured number, compound 3's estimate is 0.17 log units below it; measured number inside the range.
By their numbers in this assay, from the lowest: compounds 1, 2 and 3 (each within the scatter of the next).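

In this assay, going by these compounds alone, benzyl in place of 4-methoxyphenoxy on this aromatic carbon of the shared core gives a number 0.19 log units higher from compound 2 to compound 3 (within the scatter), the first step at a position where compound 1 and compound 2 carry the same group. The change takes the substituent from 9 heavy atoms to 7 and from 2 hydrogen-bond acceptors to 0 while keeping one six-membered aromatic ring of carbon only, and the read-out does not separate the two groups beyond the scatter. No measurement at hand accounts for how the read-out behaves at this position.

Both groups shown on this carbon carry an aromatic ring of carbon only, so the response to a group without that ring, such as a carboxylic acid or a small amine, remains open. Also open is whether a longer chain between the two amine nitrogens would move the read-out, since the chain itself stays the same across the three compounds shown.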